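The source may hold more compounds than are shown below. What is called first, only, known or untested is meant among the compounds shown, and "the series" means these compounds.

Series notes. For the measured compounds named here, compound 1 `COc1ccc(C(=O)Nc2ccccc2C)cc1OC1CCCC1` is the reference point; in an assay on isolated protein for inhibition of phosphodiesterase 4A (Sus scrofa) (on this read-out higher numbers stand for weaker inhibition and lower numbers for stronger inhibition), compound 1 gives 300 nM, the only plain number in this set so far. Compound 2 `COc1ccc(C(=O)Nc2ccccc2Cl)cc1OC(=O)c1ccccc1` yields no number in this assay: for compound 2 the read-out is a limit, > 1000000 nM. That entry is the limit of > 1000000 nM in this assay, at which 1 of the 2 values shown sits. Going by the values given here, no pair of measured compounds differing in a single place exists here, so no measured step is available for comparison. Compound 3 `COc1ccc(C(=O)Nc2c(Br)cncc2Br)cc1OC1CCCC1` is not yet measured in this assay. Relative to compound 1 the change is 3,5-dibromopyridin-4-yl in place of 2-methylphenyl on an amide-type nitrogen. Among the compounds with values here, with no measured step to lean on, a step from compound 1 to compound 3 of a 30-fold lower number from compound 1 to compound 3 (1.48 log units; beyond the scatter) toward stronger inhibition is expected, beyond the usual scatter. For compound 3 in this assay the estimate is 10 nM, within a range from 1 nM to 100 nM.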

Compound 3, half-maximal inhibitory concentration: 7 nM
Compound 3: the middle estimate sits 1.4-fold (0.15 log units) above what was measured, and the stated range covers the measured number.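

In this assay, for the compounds shown here, the substituent on the amide-type nitrogen proves to matter: 3,5-dibromopyridin-4-yl in place of 2-methylphenyl gives a 43-fold lower number from compound 1 to compound 3 (1.63 log units; beyond the scatter), a large step toward stronger inhibition and the only measured single-place step. The change replaces a carbon-only aromatic ring with one holding a ring nitrogen and two bromine atoms, and this one step cannot separate the contributions of those atoms. Going by these compounds alone, nothing measured so far accounts for the size of the step.

Still open, from the compounds shown here alone, is whether the ring nitrogen or the bromine atoms carry the gain, which a plain pyridin-4-yl or a 3,5-dichloropyridin-4-yl on the same nitrogen would test. Compound 2, whose read-out of > 1000000 nM is a limit and not a number, differs from compound 1 in more than one place, so its result cannot be assigned to either change.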